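Compound 3 at the assay limit, compound 4 next

The compounds below may be only part of what the source reports. "The series", "measured", "known", "first", "only" and "open" are said of these compounds alone.

In a functional assay on NCI-H3255 cells (Homo sapiens) for antiproliferative activity, read by MTT assay, with a stated time of 72 h (on this read-out higher numbers stand for weaker inhibition and lower numbers for stronger inhibition), compound 1 `CCOc1ccc(Nc2cc(NC(=O)c3ccccc3)ncn2)cc1` gives 9170 nM, and compound 2 `O=C(O)CCC(=O)Nc1cc(Nc2ccc(Cl)cc2)ncn1` gives 4370 nM. Compound 3 `COc1ccc(OC)c(Nc2cc(Nc3ccc(F)cc3)ncn2)c1` returns only a limit, > 30000 nM, and not a number. Its standing in the series is therefore (the limit of > 30000 nM in this assay, at which 1 of the 3 values shown sits).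

Compound 4 `COc1cccc(Nc2cc(Nc3cc(OC)ccc3OC)ncn2)c1` carries 3-methoxyphenyl in place of 4-fluorophenyl on a nitrogen on an aromatic ring. Among the measured compounds shown here, no measured pair isolates this change, and the expectation has only the limit to start from. In this assay the expected step is small, with no clear direction and nothing beyond the scatter: an at least 1.0-fold lower number from compound 3 to compound 4 (0.02 log units; that floor lies within the scatter). Compound 4 is estimated at 28000 nM, with an expected range from 9000 nM to 60000 nM.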

Compound 4, half-maximal inhibitory concentration: 860 nM
Compound 4: the middle estimate sits 33-fold (1.51 log units) above what was measured, outside the stated range (below it).
By their numbers in this assay, from the lowest: compound 4; then compound 2; then compound 1. At a limit, above all of these: compound 3.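

In this assay, 3-methoxyphenyl in place of 4-fluorophenyl on a nitrogen on an aromatic ring gives an at least 34-fold lower number from compound 3 to compound 4 (1.54 log units; beyond the scatter), the first single-place step read in the series. Among the compounds shown here, the number at this place thus depends strongly on the group it carries, which no earlier pair could show. Compound 3 holds only a limit, so the full size of the step stays unread: the limit of > 30000 nM in this assay, at which 1 of the 4 values shown sits.

Open, on these data alone, is whether the methoxy group or its ring position carries the step; a 4-methoxyphenyl or 3-fluorophenyl group here would separate the two. As far as these compounds go, how an aminophenyl group would read at this place also remains open.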